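This account rests on a few compounds, and the source may have more. Where it says the series, first, only, none or still open, it means among the compounds named here.

Among the measured compounds shown here, compound 3 `CN(C(=O)c1ccc([N+](=O)[O-])cc1)c1ccc2[nH]c(-c3n[nH]c4ccccc34)cc2n1` is the weakest of the three compounds measured so far in a functional assay on HL-60 cells (Homo sapiens) for antiproliferative activity, read by MTT assay, with a stated time of 72 h; a lower number here means a stronger inhibitor, a higher number a weaker inhibitor; in that test compound 3 gives 6800 nM. Compound 1 `CN(C(=O)c1ccc(Br)cc1)c1ccc2[nH]c(-c3n[nH]c4ccccc34)cc2n1` gives 1080 nM, and compound 2 `COc1cccc(C(=O)N(C)c2ccc3[nH]c(-c4n[nH]c5ccccc45)cc3n2)c1` gives 1420 nM. The step of a 1.3-fold higher number from compound 1 to compound 2 (0.12 log units; within the scatter) is small, whereas the steps of a 6.3-fold higher number from compound 1 to compound 3 (0.80 log units; beyond the scatter) and a 4.8-fold higher number from compound 2 to compound 3 (0.68 log units; beyond the scatter) show that the 4-nitrophenyl group weakens the compound by a modest but clear margin.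

Compound 4 `COc1ccc(NC(=O)N(C)c2ccc3[nH]c(-c4n[nH]c5ccccc45)cc3n2)cc1` is not yet measured. It differs from compound 3 in one place: (4-methoxyphenyl)amino in place of 4-nitrophenyl on a carbonyl carbon. The change removes the 4-nitrophenyl group, which in both steps to compound 3 went with a weaker inhibitor, so the two steps toward compound 3 suggest that undoing it should recover a similar amount. For the measured compounds named here, the new (4-methoxyphenyl)amino group has no counterpart among the measured compounds, so how far the recovery goes is uncertain. For compound 4 the expected step is a 3.8-fold lower number from compound 3 to compound 4 (0.58 log units; beyond the scatter), which corresponds to an estimate of 1800 nM, with a range from 600 nM to 6000 nM.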

Compound 4, half-maximal inhibitory concentration: 7.9 nM
Beside the measured number, compound 4's estimate is 230-fold (2.36 log units) above it, and the stated range ends above it.
By their numbers in this assay, from the lowest: compound 4; then compounds 1 and 2 (each within the scatter of the next); then compound 3.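

In this assay, the group on this carbonyl carbon matters far more than the three earlier groups suggested: (4-methoxyphenyl)amino gives an 860-fold lower number from compound 3 to compound 4 (2.93 log units; beyond the scatter) and also a 180-fold lower number from compound 2 to compound 4 (2.25 log units; beyond the scatter) and a 140-fold lower number from compound 1 to compound 4 (2.14 log units; beyond the scatter). The gain is therefore not just the loss of the 4-nitrophenyl group, since it is also large against the two better earlier compounds, and the entering group is the only one of the four that brings an amino nitrogen and a hydrogen-bond donor to this place. Nothing available explains why the gain is so large.

Going by these compounds, it remains open whether the amino nitrogen, the methoxy group or the two together account for the gain. A plain phenylamino group, or a (4-methoxyphenyl)methyl group with carbon in place of that nitrogen, would help separate these.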